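Cytotoxicity notes: aryl swap on the shared core

The source may hold more compounds than are shown below. What is called first, only, known or untested is meant among the compounds shown, and "the series" means these compounds.

Measured compounds in an ADME assay on Vero cells (Chlorocebus sabaeus) for cytotoxicity, read by MTT assay, with a stated time of 72 h; a lower number here means that less compound is tolerated, a higher number that more compound is tolerated:
compound 1, `C[C@]1(CN2CCc3nc(-c4ccc(C#N)cc4)ccc3C2)Cn2cc([N+](=O)[O-])nc2O1`, result: "not determined" (no result reported)
compound 2, `C[C@]1(CN2CCc3nc(-c4cc(Cl)ccc4F)ccc3C2)Cn2cc([N+](=O)[O-])nc2O1`, result: > 32 ug/mL
compound 3, `C[C@]1(CN2CCc3nc(-c4cc(F)c(F)c(F)c4)ccc3C2)Cn2cc([N+](=O)[O-])nc2O1`, not yet measured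

Compound 2 carries a 5-chloro-2-fluorophenyl on the shared core. In this assay compound 2 gives > 32 ug/mL, which is a limit of the assay and not a number. For the measured compounds named here, that limit, (the limit of > 32 ug/mL in this assay, at which 1 of the 2 values shown sits), is the only value of the pair that says anything; for compound 1 no result is reported, so no step between measured compounds can be given.

Compound 3 differs from compound 2 by 3,4,5-trifluorophenyl in place of 5-chloro-2-fluorophenyl on an aromatic carbon. Going by the values given here, with no measured step to lean on, the expectation for this exchange in this assay is no change beyond the usual scatter, in either direction. Compound 3 is therefore expected to sit near 40 ug/mL, between 16 ug/mL and 100 ug/mL, most likely again reported only as a limit. The step that this estimate implies, a step that the limit leaves unreadable from compound 2 to compound 3, is expected to be flat.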

Compound 3, half-maximal cytotoxic concentration: > 32 ug/mL
Compound 3 gave a limit, no number; the forecaster's own chance of this, stated with the estimate: 70%; the middle value does not contradict the limit.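

No step can be read between compound 2 and compound 3 in this assay: both results are limits of the assay and not numbers. Both compounds sit at the same limit: the limit of > 32 ug/mL in this assay, at which 2 of the 3 values shown sit.

The compounds shown leave open how much compound is tolerated beyond that limit, and whether exchanging 5-chloro-2-fluorophenyl for 3,4,5-trifluorophenyl changes the result at all.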